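This account rests on a few compounds, and the source may have more. Where it says the series, first, only, none or still open, it means among the compounds named here.

Measured compounds in the series:

- compound 1 `COc1ccc2c(/C=C(\C)C(=O)c3cc(OC)c(OC)c([Se]C)c3)cn(C)c2c1`: 26 nM
- compound 3 `COc1cc(C(=O)/C(C)=C/c2cn(C)c3ccccc23)cc([Se]C)c1OC`: 35 nM
- compound 2 `COc1cc(C(=O)/C=C/c2cn(C)c3ccccc23)cc([N+](=O)[O-])c1OC`: 1890 nM

Notes. In a functional assay on A2780 cells (Homo sapiens) for antiproliferative activity, read by MTT assay, with a stated time of 48 h (on this read-out lower numbers stand for stronger inhibition and higher numbers for weaker inhibition), compound 1 gives 26 nM and compound 3 gives 35 nM. The two are related by a single change, (methoxy in place of hydrogen on an aromatic carbon), and the step is a 1.3-fold lower number from compound 3 to compound 1 (0.13 log units; within the scatter), so the two values cannot be told apart here. Compound 2 gives 1890 nM in this assay, the highest number of the three; the difference between its core and the core of compound 3 is not broken down here.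

Compound 4 `COc1ccc2c(/C=C/C(=O)c3cc(OC)c(OC)c([N+](=O)[O-])c3)cn(C)c2c1` has not yet been measured in this assay. It stands to compound 2 as compound 1 stands to compound 3: the change is methoxy in place of hydrogen on an aromatic carbon, the same change as methoxy in place of hydrogen on an aromatic carbon, at the same kind of place. Among the compounds with values here, the one earlier example of this change gave a 1.3-fold lower number from compound 3 to compound 1 (0.13 log units; within the scatter), a step that stays within the scatter, so there is no ground for expecting a real shift on the core of compound 2 either. Within the data shown here, the step from compound 2 to compound 4 in this assay is expected to be a 1.3-fold lower number from compound 2 to compound 4 (0.10 log units; within the scatter), resting on the earlier step of a 1.3-fold lower number from compound 3 to compound 1 (0.13 log units; within the scatter) alone; the only other compound, compound 2, contributes its value but no step for this change. On that basis compound 4 is estimated at 1500 nM in this assay, with a range of 600 nM to 4000 nM expected to cover the repeat scatter and the uncertainty of carrying one step across to a different core.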

Compound 4, half-maximal inhibitory concentration: 952 nM
Compound 4: middle estimate off by 1.6-fold (0.20 log units), on the high side; the measured number falls inside the stated range.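

In this assay, methoxy in place of hydrogen on an aromatic carbon gives a 2.0-fold lower number from compound 2 to compound 4 (0.30 log units; within the scatter), so this change produces no shift that can be told from repeat scatter. Set beside the earlier example, the change reads the same on both cores, and carrying it from one core to the other is supported only in this limited sense: the same change on two cores in this assay, a 1.3-fold lower number (0.13 log units; within the scatter) from compound 3 to compound 1 and a 2.0-fold lower number (0.30 log units; within the scatter) from compound 2 to compound 4, 1.5-fold (0.17 log units) apart, within the scatter of two such steps

This does not show that methoxy is without effect at this place in general, since the finding rests on just two pairs, and it says nothing about cores beyond these two or about what separates these two cores, which differ in more than this one place.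

The compounds shown hold only hydrogen or methoxy on this aromatic carbon, so it remains open whether a hydroxyl group, an amine or a longer alkoxy chain there would give a step beyond the scatter. Also open, as far as these compounds go, is whether the methoxy step would stay within the scatter on a third core, or in a read-out other than this assay.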